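Replacing 4-nitrophenyl with 2,3-dichlorophenyl, with one number to go on

The compounds below may be only part of what the source reports. "The series", "measured", "known", "first", "only" and "open" are said of these compounds alone.

Going by the values given here, in a functional assay on HeLa cells (Homo sapiens) for cytotoxicity, read by MTT assay, with a stated time of 72 h (a lower number here means a stronger inhibitor, a higher number a weaker inhibitor), compound 1 `O=C(/C=C/c1ccc([N+](=O)[O-])cc1)Nc1cc2c(Nc3ccc(F)c(Cl)c3)ncnc2cc1O[C@H]1CCOC1` gives 27400 nM and is the only compound with a number. For compound 2 `COc1cc2ncnc(Nc3ccc(F)c(Cl)c3)c2cc1NC(=O)/C=C/c1ccc(F)cc1Cl` the record reads "not determined" (no result reported) and for compound 3 `COc1ccc(OC)c(/C=C/C(=O)Nc2cc3c(Nc4ccc(F)c(Cl)c4)ncnc3cc2OC)c1` it reads "not determined" (no result reported) so neither offers a comparison. Compound 4 `O=C(/C=C/c1cccc(Cl)c1Cl)Nc1cc2c(Nc3ccc(F)c(Cl)c3)ncnc2cc1O[C@H]1CCOC1` is still unmeasured. It differs from compound 1 by a single change 2,3-dichlorophenyl in place of 4-nitrophenyl on a double-bonded chain carbon bound to a double-bonded chain carbon with 2,3-dichlorophenyl in place of 4-nitrophenyl on a double-bonded chain carbon bound to a double-bonded chain carbon. Among the compounds with values here, no measured pair shows what such a swap does, so no step beyond the usual scatter is expected in this assay here. The expected step of a 1.4-fold lower number from compound 1 to compound 4 (0.14 log units; within the scatter) is therefore small. For compound 4 the estimated value is 20000 nM with an expected range from 7000 nM to 50000 nM awaiting measurement.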

Compound 4, half-maximal inhibitory concentration: 30500 nM
For compound 4 the middle estimate is 1.5-fold (0.18 log units) below the measured one; low and high end bracket the measured number.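

In this assay, going by these compounds alone, the swap gives a 1.1-fold higher number from compound 1 to compound 4 (0.05 log units; within the scatter) and so offers the first measured comparison at this position: on this chain, 2,3-dichlorophenyl and 4-nitrophenyl cannot be told apart. The rest of the molecule is the same in both compounds, so the result concerns this one change alone. No measurement shown offers an explanation for this result. On these data alone, whether an aminophenyl or a carboxyphenyl group here would give a different reading remains open, as does the effect of a longer chain between the ring and the amide carbonyl.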